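Removing the benzyl from the sulfur of compound 2

This account rests on a few compounds, and the source may have more. Where it says the series, first, only, none or still open, it means among the compounds named here.

Working notes on the series. Compound 1 `Nc1nc2cc(Cl)c(Cl)cc2n1COC(CO)CO` carries an amino group on the shared core. In a functional assay on KB cells (Homo sapiens) for inhibition (on this read-out lower numbers stand for stronger inhibition and higher numbers for weaker inhibition), compound 1 returns only a limit of the assay, > 100000 nM. Compound 2 `OCC(CO)OCn1c(SCc2ccccc2)nc2cc(Cl)c(Cl)cc21` has benzylsulfanyl in place of amino on an aromatic carbon. In this assay compound 2 likewise returns only a limit of the assay, > 100000 nM. The step that the two limits leave unreadable from compound 1 to compound 2 therefore cannot be read, as the limit of > 100000 nM in this assay, at which 2 of the 2 values shown sit, shows. Compound 2 thus stands at the limit of the assay, without a number of its own.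

Compound 3 `OCC(CO)OCn1c(S)nc2cc(Cl)c(Cl)cc21` is still to be measured in this assay. Its difference from compound 2 is hydrogen in place of benzyl on a sulfur. For the measured compounds named here, no measured step bears on this change; the only step recorded is itself unreadable, and no member of the series has yet given a number below the limit. The expected step is accordingly a number no higher from compound 2 to compound 3 (the limit leaves the size open). Compound 3 is estimated at 100000 nM, with a range from 30000 nM to 300000 nM, and most probably reported again only as a limit.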

Compound 3, half-maximal inhibitory concentration: > 100000 nM
Compound 3 was reported as a limit (the forecaster's own chance of this, stated with the estimate: 80%); the middle value sits exactly at the limit.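

In this assay compound 3 returns only a limit of the assay, > 100000 nM. For the compounds shown here, no step among compound 1, compound 2 and compound 3 can therefore be read: the limit of > 100000 nM in this assay, at which 3 of the 3 values shown sit. The compounds shown leave open how amino, benzylsulfanyl and sulfanyl on the shared core compare in this assay; none of the three has a number of its own.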